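The compounds below may be only part of what the source reports. "The series", "measured", "known", "first", "only" and "open" are said of these compounds alone.

Measured so far:
- compound 1 `CC1=C\C[C@H](O)/C=C/C(C)=C/[C@@H](NC(=O)[C@H](C)O)[C@@H](C)C(=O)/C(C)=C/C[C@H](O)\C=C\1`: > 100000 nM
- compound 2 `CC(=O)C(=O)N[C@@H]1/C=C(C)/C=C/[C@@H](O)C/C=C(C)/C=C/[C@@H](O)C/C=C(\C)C(=O)[C@H]1C`: > 100000 nM

In a functional assay on A549 cells (Homo sapiens) for cytotoxicity, read by MTT assay, with a stated time of 72 h (on this read-out higher numbers stand for weaker inhibition and lower numbers for stronger inhibition), compound 1 gives > 100000 nM, which is a limit of the assay rather than a number. Compound 2 gives > 100000 nM in this assay, again only a limit. Both results sit at the limit of > 100000 nM in this assay, at which 2 of the 2 values shown sit.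

Compound 3 `CC(=O)C(=O)N[C@@H]1/C=C(C)/C=C/[C@@H](O)C/C=C(C)/C=C/[C@@H](O)C/C=C(\C)C(=O)[C@@H]1C` is the next to be measured. the two compounds have the same atoms and bonds and differ only in configuration as drawn: 1 of 9 stereo elements differ; a stereocentre at a saturated ring carbon is drawn S in compound 2 and R in compound 3

No step between measured compounds is shown, so no measured direction is available. With compound 2 at a limit, the expected step of a number no higher from compound 2 to compound 3 (the limit leaves the size open) is none beyond the scatter. Compound 3 is therefore estimated at 100000 nM, with a range from 50000 nM to 300000 nM, most likely reported once more as a limit.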

Compound 3, half-maximal inhibitory concentration: > 100000 nM
Compound 3: no number, only a limit; the forecaster's own chance of this, stated with the estimate: 85%; the middle value sits exactly at the limit.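

No step can be read among compound 1, compound 2 and compound 3, each reported only as a limit: the limit of > 100000 nM in this assay, at which 3 of the 3 values shown sit.

Left open is whether the configuration at the saturated ring carbon, or acetyl in place of 1-hydroxyethyl, alters cytotoxicity at all.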